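Shortening a Side Chain on a Weak Modulator

The source may hold more compounds than are shown below. What is called first, only, known or untested is meant among the compounds shown, and "the series" means these compounds.

Two compounds with a shared core were tested in an assay on HEK293 cells for positive allosteric modulation of metabotropic glutamate receptor 3 (Rattus norvegicus), read by thallium flux, with a stated time of 2.5 min; a lower number here means a smaller maximal response, a higher number a larger maximal response. Compound 1, with the structure `COc1ccc(C(=O)O)cc1OCCCCOc1ccc(C(=O)C(C)C)c(O)c1C`, gives 59.9% in this assay. Compound 2, with the structure `CCC(=O)c1ccc(OCCCCOc2cccc(C(=O)O)c2C)c(C)c1O`, gives 16.3% in this assay. Of these two numbers, compound 2 stands lowest, and the nearest number, that of compound 1, lies higher by a gap that is beyond the usual scatter; the two values of compound 1 and compound 2 show only that difference, and no further reading of it is offered here.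

Compound 3, with the structure `CC(=O)c1ccc(OCCCCOc2cccc(C(=O)O)c2C)c(C)c1O`, has not yet been measured in this assay. It differs from compound 2 in one place: hydrogen in place of methyl on a saturated chain carbon bound to a carbonyl carbon. Put another way, the propanoyl group becomes an acetyl group.

Among the compounds with values here, no measured pair in this set shows a change of this kind, so the expected step is small. The step from compound 2 to compound 3 in this assay is estimated as a number 3.7 percentage points higher from compound 2 to compound 3 (within the scatter), which is not expected to go beyond the scatter in either direction. Compound 3 is therefore expected to give about 20% in this assay, with a range from 5% to 45%.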

Compound 3, largest response reached (reported as percent of maximum), in percent of the reference or control that the assay uses: 17.1%
For compound 3 the middle estimate is 2.9 percentage points above the measured one, within the range that was stated.
By their numbers in this assay, from the lowest: compounds 2 and 3 (each within the scatter of the next); then compound 1.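

Trimming the propanoyl group to an acetyl group gives the first step in this set that can be read at a single place, and in this assay it is a number 0.8 percentage points higher from compound 2 to compound 3 (within the scatter). Compound 2 and compound 3 therefore cannot be told apart by their maximal response, so this one methyl, on a saturated chain carbon bound to a carbonyl carbon, makes no measurable difference on this core. Nothing at hand gives a reason for this result, whether from structural work or from any other measurement.

The compounds shown leave open what a longer chain at this place, such as a butanoyl group, would do, and what an amine or a carboxylic acid carried on that saturated chain carbon would do. This single pair also cannot say whether the same swap of hydrogen for methyl would read the same way on a compound with a higher maximal response, where a small step might be easier or harder to see.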